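The source may hold more compounds than are shown below. What is called first, only, known or untested is meant among the compounds shown, and "the series" means these compounds.

Compound 1 (`CC1=C(C(C)C(=O)N(C)CCN(C)C)c2cc(F)ccc2/C1=C\c1ccc([S+](C)[O-])cc1`) is tested in a functional assay on MDA-MB-231 cells (Homo sapiens) for inhibition, read by CellTiter-Glo, with a stated time of 96 h; on this read-out higher numbers stand for lower toxicity in this test and lower numbers for higher toxicity in this test. Compound 1 gives only a limit there, > 50000 nM. Compound 2 (`CC1=C(C(C)C(=O)N2CCN(CCN(C)C)CC2)c2cc(F)ccc2/C1=C\c1ccc([S+](C)[O-])cc1`), which carries 4-(2-(dimethylamino)ethyl)piperazin-1-yl in place of (2-(dimethylamino)ethyl)(methyl)amino on a carbonyl carbon, also returns a limit in this assay, > 50000 nM. The step that the two limits leave unreadable from compound 1 to compound 2 is therefore not readable, because the limit of > 50000 nM in this assay, at which 2 of the 2 values shown sit, holds for both of these values. Compound 3 (`CC1=C(C(C)C(=O)N(C)CCN(C)C(=O)[C@@H](N)C(C)C)c2cc(F)ccc2/C1=C\c1ccc([S+](C)[O-])cc1`) differs from compound 1 by (1-amino-2-methylpropyl)carbonyl in place of methyl on an amine nitrogen. Within the data shown here, no measured step bears on this change, and compound 1 itself stands only at the limit. On these numbers no step beyond the scatter is expected, so that the expected change is a number no higher from compound 1 to compound 3 (the limit leaves the size open). Compound 3 is accordingly estimated at 50000 nM, with a range from 20000 nM to 120000 nM, and most likely a limit again.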

Compound 3, half-maximal cytotoxic concentration: 47600 nM
Beside the measured number, compound 3's estimate is 1.1-fold (0.02 log units) above it; low and high end bracket the measured number.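

On the amine nitrogen whose other neighbours are saturated chain carbons, (1-amino-2-methylpropyl)carbonyl can replace methyl, and compound 3 then gives 47600 nM in this assay, the only number shown rather than a limit. As far as these compounds go, the change is an at least 1.0-fold lower number from compound 1 to compound 3 (0.02 log units; that floor lies within the scatter), so it shows no shift beyond the scatter, and its true size stays open. Compound 1 and compound 2 remain at a limit, and the step between them cannot be read: the limit of > 50000 nM in this assay, at which 2 of the 3 values shown sit.

The compounds shown leave open whether a plain acetyl group on the same amine nitrogen would also give a number rather than a limit. They also leave open what the amine within (1-amino-2-methylpropyl)carbonyl contributes, and whether the opposite configuration at its stereocentre would read the same in this assay.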